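Hydroxy to methoxy on a shared chromone-derived core

The source may report more compounds than this note shows. Statements on the series, on what has been measured and on what is new or still open speak of the compounds shown alone.

Measured compounds:
Compound 1, `COc1ccc(CNC(=O)/C=C/c2coc3cc(OC)ccc3c2=O)cc1`, in a functional assay on Huh-7 cells (Homo sapiens) for inhibition, read by MTT assay, with a stated time of 48 h (on this read-out lower numbers stand for stronger inhibition and higher numbers for weaker inhibition), compound 1 gives 7570 nM.
Compound 2, `Cc1ccccc1NC(=O)/C=C/c1coc2cc(O)ccc2c1=O`, in this assay compound 2 gives 11100 nM.

Within the data shown here, only two compounds have numbers, and compound 2 gives the higher of them; the gap between compound 2 and compound 1 lies within the usual scatter of this assay, so the two cannot be ranked against each other. Compound 3, `COc1ccc2c(=O)c(/C=C/C(=O)Nc3ccccc3C)coc2c1`, has not yet been measured. It differs from compound 2 in one place: methyl in place of hydrogen on an oxygen on an aromatic ring. Among the measured compounds shown here, no measured pair shows this change on its own. Compound 1, which already carries the methoxy, gives 7570 nM, close to compound 2, so the step from compound 2 to compound 3 is expected to stay inside the scatter, with a slight lean toward a lower number at most. Compound 3 is therefore expected to give about 8500 nM, within 3500 nM to 20000 nM, an expected step of a 1.3-fold lower number from compound 2 to compound 3 (0.12 log units; within the scatter).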

Compound 3, half-maximal inhibitory concentration: 26900 nM
The estimate for compound 3 lay 3.2-fold (0.50 log units) below the measured number, and the stated range ends below it.
By their numbers in this assay, from the lowest: compounds 1 and 2 (each within the scatter of the next); then compound 3.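

In this assay, the hydroxy to methoxy change on the shared core is now seen on its own, and on this oxygen the methyl goes with weaker inhibition (a 2.4-fold higher number from compound 2 to compound 3 (0.38 log units; beyond the scatter)). The methoxy on this oxygen therefore does not by itself give a number like that of compound 1: with the methoxy held in both, 2-methylphenyl in place of 4-methoxybenzyl on the amide-type nitrogen also goes with weaker inhibition (a 3.6-fold higher number from compound 1 to compound 3 (0.55 log units; beyond the scatter)). No measurement at hand accounts for either step.

Still open, on these data alone, is whether the hydroxy to methoxy step keeps its size when 4-methoxybenzyl sits on the amide-type nitrogen. The compounds shown also leave open how a longer ether such as ethoxy, or an amine, would read on this aromatic ring.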